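Swapping the diene chain on compound 3

The source may hold more compounds than are shown below. What is called first, only, known or untested is meant among the compounds shown, and "the series" means these compounds.

In a functional assay on the whole organism with Canis familiaris (Canis lupus familiaris) as the target (a higher number here means that more compound is needed for the effect, a lower number that less compound is needed), compound 1 `C/C=C\C=C\[C@](C)(O)C/C=C/[C@H]1[C@H](O)CC(=O)[C@@H]1CC/C=C\CCC(=O)OC` gives 0.0000099 mg/kg, compound 2 `COC(=O)CC/C=C\CC[C@H]1C(=O)C[C@@H](O)[C@@H]1/C=C/C[C@@](C)(O)/C=C/C=C(C)C` gives 0.00006 mg/kg and compound 3 `C=C/C(C)=C/[C@](C)(O)C/C=C/[C@H]1[C@H](O)CC(=O)[C@@H]1CC/C=C\CCC(=O)OC` gives 0.00071 mg/kg. Compound 3 has the highest number of the three, so it needs the most compound for the effect.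

Compound 4 `C/C=C(C)/C=C/[C@](C)(O)C/C=C/[C@H]1[C@H](O)CC(=O)[C@@H]1CC/C=C\CCC(=O)OC` keeps the rest of compound 3 but carries 3-methylpenta-1,3-dien-1-yl in place of 2-methylbuta-1,3-dien-1-yl, on a saturated chain carbon bound to an oxygen on a saturated carbon and two saturated chain carbons (3-methylpenta-1,3-dien-1-yl in place of 2-methylbuta-1,3-dien-1-yl on a saturated chain carbon bound to an oxygen on a saturated carbon and two saturated chain carbons).

Within the data shown here, three measured steps bear on this change. Two are large and involve this same place: a 72-fold higher number from compound 1 to compound 3 (1.86 log units; beyond the scatter) and a 12-fold higher number from compound 2 to compound 3 (1.07 log units; beyond the scatter). In both, a penta-1,3-dien-1-yl type chain gives way to 2-methylbuta-1,3-dien-1-yl and the number rises. Compound 4 reverses that kind of swap, so a clear fall in this assay is expected. The third step, a 6.1-fold higher number from compound 1 to compound 2 (0.78 log units; beyond the scatter), shows that a methyl on the pentadienyl chain can raise the number modestly, and the methyl in compound 4 sits elsewhere on that chain, so the outcome remains uncertain.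

The expected change is a fall, estimated as an 18-fold lower number from compound 3 to compound 4 (1.25 log units; beyond the scatter). For compound 4 the estimated value is 0.00004 mg/kg, with an expected range of 0.000007 mg/kg to 0.0003 mg/kg.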

Compound 4, dose for half-maximal effect: 0.000003 mg/kg
Beside the measured number, compound 4's estimate is 13-fold (1.12 log units) above it; measured number below the stated range.
By their numbers in this assay, from the lowest: compound 4; then compound 1; then compound 2; then compound 3.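

In this assay, 3-methylpenta-1,3-dien-1-yl in place of 2-methylbuta-1,3-dien-1-yl gives a 240-fold lower number from compound 3 to compound 4 (2.37 log units; beyond the scatter), the largest step among these four compounds and one that leaves compound 4 with the lowest number of the set. The earlier compounds shown here showed that this chain matters, but the next step shows how much depends on where a methyl sits on it: 1-methylprop-1-en-1-yl in place of 2-methylprop-1-en-1-yl gives a 20-fold lower number from compound 2 to compound 4 (1.30 log units; beyond the scatter). A methyl on the chain can also move the number either way, since compound 2 went up from compound 1, whereas 1-methylprop-1-en-1-yl in place of prop-1-en-1-yl gives a 3.3-fold lower number from compound 1 to compound 4 (0.52 log units; beyond the scatter).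

The compounds shown leave open whether this place would tolerate a chain with no second double bond, a longer chain such as a heptadienyl, or a chain ending in an amine or a carboxylic acid. Nothing in the information available explains why moving one methyl changes the dose needed so strongly.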